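Allylsulfanyl in place of hydroxy on a carbonyl carbon

A few compounds are considered here, and "the series" means these few. Any claim that something is new, unique, unknown or untested is made for them only; others in the source may bear on it.

Compound 1 `CCCOC(=O)/C=C(C)/C=C/CC(C)CCCC(C)C` at 7.28
Compound 2 `CC(/C=C/CC(C)CCCC(C)C)=C\C(=O)O` at 5.95

In a physicochemical assay for lipophilicity (on this read-out higher numbers stand for higher lipophilicity and lower numbers for lower lipophilicity), compound 2 stands lowest of the two measured compounds, its 5.95 lying beyond the scatter from compound 1. Compound 3 `C=CCSC(=O)/C=C(C)/C=C/CC(C)CCCC(C)C` differs from it by allylsulfanyl in place of hydroxy on a carbonyl carbon and so carries allylsulfanyl in place of hydroxy on a carbonyl carbon. Among the measured compounds shown here, the one measured step bearing on this took away propyl. It is a number 1.33 log units lower from compound 1 to compound 2 (beyond the scatter) and counts as large, so a similar step in the opposite direction is expected in this assay on going to allylsulfanyl. The expected step is a number 1.25 log units higher from compound 2 to compound 3 (beyond the scatter) overall. For compound 3 the estimated value is 7.2 (expected range 6.7 to 7.7).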

Compound 3, partition coefficient: 7.97
The estimate for compound 3 lay 0.77 log units below the measured number, outside the stated range (above it).
By their numbers in this assay, from the lowest: compound 2; then compound 1; then compound 3.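

In this assay, allylsulfanyl in place of hydroxy on a carbonyl carbon gives a number 2.02 log units higher from compound 2 to compound 3 (beyond the scatter) and sets a new high among the three compounds. The position also distinguishes between two groups that both replace hydroxy: allylsulfanyl in place of propoxy gives a number 0.69 log units higher from compound 1 to compound 3 (beyond the scatter) in this assay and so does not simply match the earlier ester. Nothing available explains these steps. The compounds shown leave open whether the sulfur or the double bond of allylsulfanyl accounts for the step from propoxy. Propylsulfanyl and allyloxy on this carbonyl carbon would separate the two.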